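The source may hold more compounds than are shown below. What is called first, only, known or untested is meant among the compounds shown, and "the series" means these compounds.

Compound 1 `Cn1nnnc1SCC(=O)N/N=C/c1ccccc1Cl` is the starting point. In an ADME assay on NIH3T3 cells (Mus musculus) for cytotoxicity, read by XTT assay, with a stated time of 24 h (a lower number here means a stronger inhibitor, a higher number a weaker inhibitor), compound 1 gives only a limit, > 10000000 nM. Compound 2 `Cn1nnnc1SCC(=O)N/N=C/c1cccc(Cl)c1Cl` gives 520000 nM in this assay, so the step of an at least 19-fold lower number from compound 1 to compound 2 (1.28 log units; beyond the scatter) goes with chloro in place of hydrogen on an aromatic carbon. Compound 3 `C/C(=N\NC(=O)CSc1nnnn1C)c1ccc(Cl)cc1` gives 100000 nM in this assay; how its core differs from the core of compound 1 is not broken down here. Compound 4 `C/C(=N\NC(=O)CSc1nnnn1C)c1ccc(Cl)cc1Cl` carries chloro in place of hydrogen on an aromatic carbon, the same kind of change, though the surroundings differ: in compound 4 the entering chloro sits ortho to a large group and meta to a chloro group, whereas in compound 2 it sits ortho to a chloro group and meta to a large group. Because (the limit of > 10000000 nM in this assay, at which 1 of the 3 values shown sits), the earlier step is known only as a bound, so a more modest step a 3.3-fold lower number from compound 3 to compound 4 (0.52 log units; beyond the scatter) is expected here. Compound 4 is estimated at 30000 nM, between 8000 nM and 110000 nM.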

Compound 4, half-maximal inhibitory concentration: 1000000 nM
The estimate for compound 4 lay 33-fold (1.52 log units) below the measured number; the measured number lies above the stated range.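

The new step, a 10-fold higher number from compound 3 to compound 4 (1.00 log units; beyond the scatter) in this assay, runs the opposite way to the earlier one, so chloro in place of hydrogen on an aromatic carbon did not carry over from one core to the other: the same change on two cores in this assay, an at least 19-fold lower number (1.28 log units; beyond the scatter) from compound 1 to compound 2 and a 10-fold higher number (1.00 log units; beyond the scatter) from compound 3 to compound 4, at least 190-fold (2.28 log units) apart, beyond the scatter of two such steps. Compound 1 stands at a limit, so the gap between the two steps is known only as a bound: the limit of > 10000000 nM in this assay, at which 1 of the 4 values shown sits. These two pairs do not show whether the core or the place of the entering chloro decides the outcome, as both differ between the pairs.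

The compounds shown leave open whether bromo or methyl at the same place on the core of compound 3 would follow the chloro step. They also leave open whether a second pair on either core would repeat its step.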